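The source may report more compounds than this note shows. Statements on the series, on what has been measured and on what is new or still open speak of the compounds shown alone.

Of the compounds shown here, three with a shared core have been measured. Compound 1 `C[C@@H]1O[C@H](N2C(=O)/C(=C3\Nc4ccccc4C3=O)c3ccccc32)[C@H](O)[C@H](O)[C@H]1O` gives 760 nM in a functional assay on MCF7 cells (Homo sapiens) for antiproliferative activity, read by crystal violet staining, with a stated time of 96 h; on this read-out higher numbers stand for weaker inhibition and lower numbers for stronger inhibition. Compound 2 `C[C@@H]1O[C@@H](N2C(=O)/C(=C3\Nc4ccccc4C3=O)c3ccccc32)[C@H](O)[C@H](O)[C@H]1O` gives 670 nM, the lowest of the three numbers, though its gap to compound 1 stays within the scatter; that step, a 1.1-fold lower number from compound 1 to compound 2 (0.05 log units; within the scatter), goes with the fact that compounds 1 and 2 differ only in the configuration as drawn. Compound 3 `C[C@@H]1O[C@H](N2C(=O)/C(=C3\Nc4ccccc4\C3=N/O)c3ccccc32)[C@H](O)[C@H](O)[C@H]1O` gives 17000 nM, far higher than the other two. Compound 4 `C[C@@H]1O[C@@H](N2C(=O)/C(=C3\Nc4ccc(Cl)cc4C3=O)c3ccccc32)[C@H](O)[C@H](O)[C@H]1O` differs from compound 2 by chloro in place of hydrogen on an aromatic carbon. Going by the values given here, no measured step involves a change of this kind: the only one available, a 1.1-fold lower number from compound 1 to compound 2 (0.05 log units; within the scatter), concerns configuration alone, so it offers no guide to adding a chloro group. Compound 4 is therefore expected to stay near compound 2, at about 500 nM, within 150 nM to 1700 nM. That estimate means a step of a 1.3-fold lower number from compound 2 to compound 4 (0.13 log units; within the scatter).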

Compound 4, half-maximal inhibitory concentration: 6960 nM
Compound 4: the middle estimate sits 14-fold (1.14 log units) below what was measured; measured number above the stated range.
By their numbers in this assay, from the lowest: compounds 2 and 1 (each within the scatter of the next); then compound 4; then compound 3.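

Chloro in place of hydrogen at this position, a change of one heavy atom, brings a 10-fold higher number from compound 2 to compound 4 (1.02 log units; beyond the scatter) in the antiproliferative read-out. So this aromatic carbon of the shared core is sensitive to substitution, which the earlier compounds could not show. Nothing measured here explains why this step is so large. From the compounds shown here alone, whether a fluoro, methoxy or amine group at this carbon would give a similar step stays open. So does whether chloro would do the same in compound 1, which has the other configuration.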